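A few compounds are considered here, and "the series" means these few. Any claim that something is new, unique, unknown or untested is made for them only; others in the source may bear on it.

Readings so far in a functional assay on K562 cells (Homo sapiens), read by MTT assay, with a stated time of 72 h; a higher number here means a weaker inhibitor, a lower number a stronger inhibitor:
- compound 1 `COc1ncnc2c1c(-c1cc3ccccc3o1)cn2[C@@H]1O[C@H](CO)[C@@H](O)[C@H]1O` gives 13100 nM
- compound 2 `CSc1ncnc2c1c(-c1ccoc1)cn2[C@@H]1O[C@H](CO)[C@@H](O)[C@H]1O` gives 3250 nM

Compound 2 stands lowest of the two, and its gap to compound 1 lies beyond the scatter. The next compound to read is compound 3 `CSc1ncnc2c1c(-c1ccccc1)cn2[C@@H]1O[C@H](CO)[C@@H](O)[C@H]1O`, with phenyl in place of furan-3-yl on an aromatic carbon and the rest of compound 2 unchanged. Among the measured compounds shown here, no measured pair isolates this change, so the expectation is loose. A modest step toward a higher number in this assay is expected, near the edge of the scatter, though no step beyond the scatter remains possible. The estimated change is a 1.8-fold higher number from compound 2 to compound 3 (0.27 log units; within the scatter) on this reading. For compound 3 the expected value is 6000 nM in this read-out, with an estimated range of 1800 nM to 20000 nM for the measurement.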

Compound 3, half-maximal inhibitory concentration: > 20000 nM
Compound 3 was reported as a limit (the forecaster's own chance of this, stated with the estimate: 15%); middle value at least 3.3-fold (0.52 log units) away from the limit.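

In this assay, among the compounds shown here, this is the first single change that can be read: phenyl in place of furan-3-yl, on the aromatic carbon two ring bonds from the ring nitrogen, gives an at least 6.1-fold higher number from compound 2 to compound 3 (0.78 log units; beyond the scatter). The step lies beyond the scatter, so this position does not treat these two aromatic rings alike, and the furan-3-yl compound keeps the lower number in this pair. Compound 3 is reported only as a limit of the assay, > 20000 nM, so the step has a lower bound and no upper one: the limit of > 20000 nM in this assay, at which 1 of the 3 values shown sits.

Whether ring size or the ring oxygen accounts for the step remains open. A thiophen-3-yl or pyridin-3-yl group at this place would bear on that question, as would a phenyl ring carrying an amine.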